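Swapping a Methoxy Tail for an Ethylpiperazinylmethyl Group

A few compounds are considered here, and "the series" means these few. Any claim that something is new, unique, unknown or untested is made for them only; others in the source may bear on it.

Three amides that share one core have been measured in a functional assay on K562 cells (Homo sapiens) for inhibition, read by MTT assay, with a stated time of 48 h; on this read-out lower numbers stand for stronger inhibition and higher numbers for weaker inhibition. Compound 1 `Cc1ccc(NC(=O)c2cccc(Cl)c2)cc1-n1cc(-c2cccnc2)cn1` gives 1320 nM, and compound 2 `Cc1ccc(NC(=O)c2ccc(C(F)(F)F)cc2)cc1-n1cc(-c2cccnc2)cn1` gives 760 nM; the step of a 1.7-fold lower number from compound 1 to compound 2 (0.24 log units; within the scatter) is small. Compound 3 `COc1ccc(C(=O)Nc2ccc(C)c(-n3cc(-c4cccnc4)cn3)c2)cc1` gives 18300 nM, the highest number of the three, and both steps toward it are large: a 14-fold higher number from compound 1 to compound 3 (1.14 log units; beyond the scatter) and a 24-fold higher number from compound 2 to compound 3 (1.38 log units; beyond the scatter). Compound 3 therefore stands clearly apart from the other two on this read-out.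

Compound 4 `CCN1CCN(Cc2ccc(C(=O)Nc3ccc(C)c(-n4cc(-c5cccnc5)cn4)c3)cc2)CC1` differs from compound 3 in one place: (4-ethylpiperazin-1-yl)methyl in place of methoxy on an aromatic carbon. Going by the values given here, no measured pair shows this exact exchange, so the expectation rests only on the fact that the two steps that touched this group, a 14-fold higher number from compound 1 to compound 3 (1.14 log units; beyond the scatter) and a 24-fold higher number from compound 2 to compound 3 (1.38 log units; beyond the scatter), were both large. A change at this position can thus shift this assay well beyond the scatter, and since compound 3 already holds the weakest number, a move back toward compounds 1 and 2 is the more likely direction. Compound 4 is expected to give about 2500 nM, within a range from 400 nM to 15000 nM, an estimated step of a 7.3-fold lower number from compound 3 to compound 4 (0.86 log units; beyond the scatter).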

Compound 4, half-maximal inhibitory concentration: 2330 nM
For compound 4 the middle estimate is 1.1-fold (0.03 log units) above the measured one, within the range that was stated.
By their numbers in this assay, from the lowest: compounds 2, 1 and 4 (each within the scatter of the next, the first and the last beyond it); then compound 3.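

Putting (4-ethylpiperazin-1-yl)methyl in place of methoxy gives a 7.9-fold lower number from compound 3 to compound 4 (0.90 log units; beyond the scatter) in this assay, so this position, para to a large group, accepts a much bulkier group carrying a six-membered non-aromatic ring without the number rising. Measured against trifluoromethyl at the same place, the new group gives a 3.1-fold higher number from compound 2 to compound 4 (0.49 log units; beyond the scatter), so it recovers much of the ground lost with methoxy but not all of it. Nothing in the data shown explains either step.

What the compounds shown leave open is which part of the new group matters: the piperazine ring, the ethyl end or the methylene link. A smaller amine such as dimethylaminomethyl, a morpholinylmethyl group or a carboxylic acid at this position could each help separate these parts.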